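Removal of the ring-nitrogen acyl group in a tetrahydroquinoline amide series

The source may report more compounds than this note shows. Statements on the series, on what has been measured and on what is new or still open speak of the compounds shown alone.

Measured so far in a functional assay on NCI-H23 cells (Homo sapiens) for cytotoxicity, read by sulforhodamine B assay, with a stated time of 72 h; on this read-out higher numbers stand for weaker inhibition of growth and lower numbers for stronger inhibition of growth:
- compound 1, `O=C(Nc1ccccc1C(F)(F)F)C1CCc2ccccc2N1C(=O)c1cccc(Cl)c1`: 292 nM
- compound 2, `COc1ccc(NC(=O)C2CCc3ccccc3N2)cc1`: 55700 nM
- compound 3, `O=C(Nc1cc(C(F)(F)F)cc(C(F)(F)F)c1)C1CCc2ccccc2N1C(=O)c1cccc(Cl)c1`: 420 nM

Compound 1 gives the lowest number of the three in this assay. Compound 3 stands nearest to it, and the gap between them lies within the scatter, so no order between compound 1 and compound 3 is claimed. Compound 2 lies furthest away, and that gap lies well beyond the scatter. Compound 2 is the only one of the three that carries a hydrogen rather than an acyl group on the ring nitrogen of the shared core.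

Compound 4, `O=C(Nc1ccccc1C(F)(F)F)C1CCc2ccccc2N1`, has not been measured. It differs from compound 1 in one place: hydrogen in place of (3-chlorophenyl)carbonyl on a nitrogen on an aromatic ring in a ring. Compound 4 therefore shares with compound 2 the free ring nitrogen, but keeps the aryl amide of compound 1. Going by the values given here, no measured pair isolates this change, so the expectation rests on compound 2 with its value of 55700 nM against the acylated pair. A large step upward in this assay is expected, from compound 1 to compound 4 estimated at a 68-fold higher number from compound 1 to compound 4 (1.84 log units; beyond the scatter). Compound 4 is estimated at 20000 nM, with a range from 4000 nM to 80000 nM.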

Compound 4, concentration for 50% growth inhibition: 56800 nM
Compound 4: the middle estimate sits 2.8-fold (0.45 log units) below what was measured; the range from low to high includes it.
By their numbers in this assay, from the lowest: compounds 1 and 3 (each within the scatter of the next); then compounds 2 and 4 (each within the scatter of the next).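

In this assay, the (3-chlorophenyl)carbonyl on the ring nitrogen is now tied to growth inhibition by a change in one place: hydrogen in its place gives a 190-fold higher number from compound 1 to compound 4 (2.29 log units; beyond the scatter). Until now, the link between a free ring nitrogen and a high number rested only on compound 2, which also differs from compound 1 in its aryl amide, whereas this pair keeps the amide of compound 1 unchanged. Nothing at hand gives a reason for the size of this step.

The compounds shown leave open whether the step depends on the (3-chlorophenyl)carbonyl in particular or on any acyl group at this nitrogen, since all the acylated compounds carry the same group there. An acetyl, a benzoyl without the chlorine or a benzyl group at this nitrogen would help separate the contributions of the carbonyl, the chlorine and the aromatic ring.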